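From 1H-pyrazol-4-yl to pyridin-2-yl in compound 4

The source may report more compounds than this note shows. Statements on the series, on what has been measured and on what is new or still open speak of the compounds shown alone.

Three compounds measured in a functional assay on MKN-45 cells (Homo sapiens) for antiproliferative activity, read by CellTiter-Glo, with a stated time of 3 days; on this read-out higher numbers stand for weaker inhibition and lower numbers for stronger inhibition:
Compound 1 `CC(Oc1c(N)ncc2c(-c3cnn(C4CCNCC4)c3)coc12)c1cc(F)ccc1Cl`: 6400 nM
Compound 2 `CC(=O)N1CCC(n2cc(-c3coc4c(O[C@H](C)c5c(Cl)ccc(F)c5Cl)c(N)ncc34)cn2)CC1`: 670 nM
Compound 3 `C[C@@H](Oc1c(N)ncc2c(-c3cn[nH]c3)coc12)c1c(Cl)ccc(F)c1Cl`: 3300 nM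

Compound 3 lies within the usual scatter of compound 1, and only compound 2 stands clearly apart from it. Compound 4 `C[C@@H](Oc1c(N)ncc2c(-c3ccccn3)coc12)c1c(Cl)ccc(F)c1Cl` carries pyridin-2-yl in place of 1H-pyrazol-4-yl on an aromatic carbon. The nearest evidence is a 4.9-fold higher number from compound 2 to compound 3 (0.69 log units; beyond the scatter), with hydrogen in place of 1-acetylpiperidin-4-yl on an aromatic nitrogen. For the measured compounds named here, no measured step replaces the whole ring, so this is only a loose guide. In this assay the estimated step is a 1.5-fold higher number from compound 3 to compound 4 (0.18 log units; within the scatter), so a slight move toward a higher number is expected, but nothing clearly beyond the scatter. The estimate for compound 4 is 5000 nM, with an expected range from 1500 nM to 16000 nM.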

Compound 4, half-maximal inhibitory concentration: 4600 nM
The estimate for compound 4 lay 1.1-fold (0.04 log units) above the measured number; low and high end bracket the measured number.
By their numbers in this assay, from the lowest: compound 2; then compounds 3, 4 and 1 (each within the scatter of the next).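

In this assay, the exchange of 1H-pyrazol-4-yl for pyridin-2-yl (a 1.4-fold higher number from compound 3 to compound 4 (0.14 log units; within the scatter)) stays within the scatter. On this aromatic carbon, then, a six-membered ring without a hydrogen-bond donor reads like the five-membered ring with one, whereas the earlier step concerned only a substituent on the pyrazole nitrogen. Nothing measured here explains this likeness. Going by these compounds, how a plain phenyl ring or an amine-bearing pyridine would read at this carbon remains open. So does whether the 1-acetylpiperidin-4-yl difference between compound 2 and compound 3 would carry over to a six-membered ring.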